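The source may report more compounds than this note shows. Statements on the series, on what has been measured and on what is new or still open speak of the compounds shown alone.

In a functional assay on Gurav cells (Homo sapiens) for inhibition, read by sulforhodamine B assay (a lower number here means a stronger inhibitor of growth, a higher number a weaker inhibitor of growth), three compounds have been measured so far. Compound 1 (`c1ccc(-c2ccc(-c3ccc(-c4nc5ccccc5[nH]4)cc3)cc2)cc1`) gives 100000 nM, and compound 3 (`Fc1ccc(-c2ccc(-c3ccc(-c4nc5ccccc5[nH]4)cc3)cc2)cc1`) gives 100000 nM, so these two stand level with each other and together hold the highest of the three numbers. Compound 2 (`Cc1ccc2[nH]c(-c3ccc(-c4ccc(-c5cccc(Cl)c5)cc4)cc3)nc2c1`) gives 2120 nM, a number well below that of compound 3.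

The next step leads to compound 4 (`FC(F)(F)c1ccc(-c2ccc(-c3ccc(-c4nc5ccccc5[nH]4)cc3)cc2)cc1`), with trifluoromethyl in place of fluoro on an aromatic carbon, para to a large group (trifluoromethyl in place of fluoro on an aromatic carbon). Among the compounds with values here, only one measured step bears on this change, as it alters the same carbon: no change at the digits printed from compound 1 to compound 3 (within the scatter). Compound 2 differs from compound 3 in more than one place, so its value cannot be read as a step at this carbon. With that single flat step as the guide, no change beyond the scatter is expected in this assay, although a trifluoromethyl group has not been tested here. The expected result is a 1.4-fold lower number from compound 3 to compound 4 (0.15 log units; within the scatter). Compound 4 is estimated at 70000 nM, with an expected range from 10000 nM to 100000 nM.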

Compound 4, concentration for 50% growth inhibition: 39100 nM
Compound 4: the middle estimate sits 1.8-fold (0.25 log units) above what was measured, and the stated range covers the measured number.
By their numbers in this assay, from the lowest: compound 2; then compound 4; then compounds 1 and 3 (each within the scatter of the next).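

The earlier swap gave no change at the digits printed from compound 1 to compound 3 (within the scatter), so this aromatic carbon looked insensitive to its substituent in this assay, but trifluoromethyl in place of fluoro gives a 2.6-fold lower number from compound 3 to compound 4 (0.41 log units; beyond the scatter), and trifluoromethyl in place of hydrogen gives the same size of step, a 2.6-fold lower number from compound 1 to compound 4 (0.41 log units; beyond the scatter). A change on this carbon can therefore move the number beyond the scatter, though only modestly, and trifluoromethyl does here what fluoro did not. No measurement is at hand that explains this difference between the two groups.

The compounds shown leave open whether other groups on this carbon, such as an amine, a carboxylic acid or a longer alkyl chain, would lower the number further or raise it. They also leave open whether trifluoromethyl would give a similar step on the core of compound 2.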